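The source may report more compounds than this note shows. Statements on the series, on what has been measured and on what is new or still open speak of the compounds shown alone.

Series notes. Compound 1 `CC(C)(C)Cc1c(Br)sc(N)c1C(=O)c1cccc(Cl)c1` gives 1% in an assay on CHO cells for displacement of a labelled ligand from adenosine receptor A1 (Homo sapiens), read by scintillation counting, tested at 10 uM; on this read-out lower numbers stand for less inhibition and higher numbers for more inhibition at the one concentration tested (going by the name of the read-out). Compound 2 `COc1ccc(-c2sc(N)c(C(=O)c3ccc(Cl)cc3)c2CC(C)(C)C)cc1` gives 1% in this assay, level with compound 1 within the scatter. Compound 3 `COc1ccc(-c2sc(N)c(C(=O)c3cccc(Cl)c3)c2CC(C)(C)C)cc1` is not yet measured; it differs from compound 2 by 3-chlorophenyl in place of 4-chlorophenyl on a carbonyl carbon. Among the measured compounds shown here, no measured step covers this change, but compound 1 already carries 3-chlorophenyl on the carbonyl carbon and gives 1%, so the step is expected to stay within the scatter, with a number 1 percentage points higher from compound 2 to compound 3 (within the scatter) near nil. Compound 3 is estimated at 2%, ranging from 0% to 12%.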

Compound 3, a percentage reported as inhibition, at one concentration (the size of the read-out at that concentration, not a potency): 1%
Compound 3: middle estimate off by 1 percentage points, on the high side; measured number inside the range.
By their numbers in this assay, from the lowest: compounds 1, 2 and 3 (each within the scatter of the next).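

In this assay the chlorophenyl on the carbonyl carbon can carry its chlorine as 3-chlorophenyl or 4-chlorophenyl with no change at the digits printed from compound 2 to compound 3 (within the scatter) and nothing gained in inhibition. Among the compounds shown here, with 3-chlorophenyl held constant, 4-methoxyphenyl in place of bromo on the aromatic carbon gives no change at the digits printed from compound 1 to compound 3 (within the scatter) and so joins the first step in leaving the read-out flat. Open, going by these compounds, is whether a pyridine ring on the carbonyl carbon, or an amine or a carboxylic acid in place of the 4-methoxyphenyl, would move the number at all. Nothing on hand accounts for these flat steps.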